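Dichloroacetanilides: halogen swap on the ring

The source may report more compounds than this note shows. Statements on the series, on what has been measured and on what is new or still open speak of the compounds shown alone.

Measured compounds:
compound 1 `O=C(Nc1cccc(Cl)c1)C(Cl)Cl`: 44500 nM
compound 2 `O=C(Nc1cccc(Br)c1)C(Cl)Cl`: 7720 nM
compound 3 `O=C(Nc1ccc(Cl)cc1)C(Cl)Cl`: 49600 nM

All three were tested in a functional assay on Bel-7402 cells (Homo sapiens) for antiproliferative activity, read by MTT assay, with a stated time of 72 h; a higher number here means a weaker inhibitor, a lower number a stronger inhibitor. Compound 3 and compound 1 are built from the same atoms joined differently; the difference between the two cores is not broken down here. Their values lie within the scatter of each other, so no order between them is claimed. Compound 2 differs from compound 1 by bromo in place of chloro on an aromatic carbon and gives a 5.8-fold lower number from compound 1 to compound 2 (0.76 log units; beyond the scatter).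

Compound 4 `O=C(Nc1ccc(Br)cc1)C(Cl)Cl` has not yet been measured. It differs from compound 3 by bromo in place of chloro on an aromatic carbon. This is the same kind of change as that from compound 1 to compound 2, but the surroundings differ: in compound 2 the bromo sits meta to a group of 6 heavy atoms, in compound 4 para to a group of 6 heavy atoms. Among the compounds with values here, only one example of the change exists, so the expectation rests on compound 2 alone, because of a 5.8-fold lower number from compound 1 to compound 2 (0.76 log units; beyond the scatter). For compound 4 a step of a 5.0-fold lower number from compound 3 to compound 4 (0.70 log units; beyond the scatter) is expected, somewhat less steep given the changed place. Compound 4 is estimated at 10000 nM, expected between 3500 nM and 30000 nM.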

Compound 4, half-maximal inhibitory concentration: 9770 nM
Compound 4: middle estimate off by 1.0-fold (0.01 log units), on the high side; low and high end bracket the measured number.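

In this assay, bromo in place of chloro on an aromatic carbon gives a 5.1-fold lower number from compound 3 to compound 4 (0.71 log units; beyond the scatter), and this step matches the earlier one on the other core: the same change on two cores in this assay, a 5.8-fold lower number (0.76 log units; beyond the scatter) from compound 1 to compound 2 and a 5.1-fold lower number (0.71 log units; beyond the scatter) from compound 3 to compound 4, 1.1-fold (0.06 log units) apart, within the scatter of two such steps

Within this small set, the change therefore carries from the core of compound 1 to the core of compound 3 with its size kept, and each bromo compound gives the lower number of its pair. Within the data shown here, this rests on only two matched pairs in a single cell line, so it does not show that the step would hold on cores altered elsewhere or in other cells, and it gives no reason why bromo gives the lower number.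

The compounds shown leave open what iodo, fluoro, an amine or a carboxylic acid would do in place of the ring halogen. Also open, as far as these compounds go, is how the bromo step would behave with the dichloromethyl group replaced by a trichloromethyl group or a longer chain, or with the amide hydrogen replaced by a methyl group.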